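A few compounds are considered here, and "the series" means these few. Any claim that something is new, unique, unknown or untested is made for them only; others in the source may bear on it.

Compound 1, `Cn1cccc1C(=O)/C=C/c1ccc2c(c1)B(O)OC2`: in a toxicity assay on MCF-10A cells (Homo sapiens) for cytotoxicity, read by MTT assay, with a stated time of 48 h (a higher number here means a weaker inhibitor, a lower number a stronger inhibitor), compound 1 gives only a limit, > 100000 nM.
Compound 2, `O=C(/C=C/c1ccc2c(c1)B(O)OC2)c1ccc(Br)cc1`: in this assay compound 2 gives 27800 nM.
Compound 3, `O=C(/C=C/c1ccc2c(c1)B(O)OC2)c1cccc(F)c1`: in this assay compound 3 gives 15800 nM.

Of the two real numbers, compound 2 holds the higher one, yet the gap a 1.8-fold lower number from compound 2 to compound 3 (0.25 log units; within the scatter) is too small to separate the two compounds. The change from compound 1 to each of the other two is larger, an at least 3.5-fold lower number from compound 1 to compound 2 (0.55 log units; beyond the scatter) and an at least 6.3-fold lower number from compound 1 to compound 3 (0.80 log units; beyond the scatter), although both steps are only lower bounds because the limit of > 100000 nM in this assay, at which 1 of the 3 values shown sits, stands at the start of each.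

Compound 4, `O=C(O)c1ccc(C(=O)/C=C/c2ccc3c(c2)B(O)OC3)cc1`, is the next compound, not yet measured. It differs from compound 2 in one place:

carboxy in place of bromo on an aromatic carbon

For the measured compounds named here, none of the measured steps swaps one substituent on a phenyl ring for another of a different kind; the two steps from compound 1 replace the whole group on the carbonyl carbon, and the step from compound 2 to compound 3 moves between two halogenated phenyl rings without leaving the scatter. There is therefore no direct guide for a carboxy in place of bromo. The expectation for compound 4 is a step of a 1.3-fold higher number from compound 2 to compound 4 (0.10 log units; within the scatter) that stays within the scatter, with the estimate for compound 4 at 35000 nM, between 12000 nM and 100000 nM.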

Compound 4, half-maximal inhibitory concentration: > 100000 nM
Compound 4: only a limit was reported; the forecaster's own chance of this, stated with the estimate: 25%; at least 2.8-fold (0.45 log units) between middle value and limit.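

Exchanging bromo for carboxy on the aromatic ring, para to a large group, gives an at least 3.5-fold higher number from compound 2 to compound 4 (0.55 log units; beyond the scatter). Among the steps shown, this is the only one that trades a single substituent on the phenyl ring for a group of a different kind, and it leaves the scatter, whereas the one earlier step between two phenyl rings, a 1.8-fold lower number from compound 2 to compound 3 (0.25 log units; within the scatter), did not; a higher number here means a weaker effect on these cells, so this single change at this position is enough to weaken it measurably. The step is only a lower bound because compound 4, in this assay, gives a limit and not a number, > 100000 nM: the limit of > 100000 nM in this assay, at which 2 of the 4 values shown sit.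

The compounds shown leave open whether the loss belongs to the carboxy itself or would follow from other replacements of bromo, such as an amine or a methyl ester in the same place. They also leave open whether a carboxy elsewhere on the ring would give the same result, and how far the true value of compound 4 lies past its limit.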